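Methyl on the nitrogen of compound 3

The compounds below may be only part of what the source reports. "The series", "measured", "known", "first", "only" and "open" are said of these compounds alone.

In a functional assay on UoC-B1 cells (Homo sapiens) for antiproliferative activity, with a stated time of 72 h (a lower number here means that less compound is needed, a higher number that more compound is needed for the effect), compound 1 `COc1ccc(-c2cc(=O)c3c(OC)cc(OC)cc3n2C)cc1` is recorded as "not determined" (no result reported) and offers no number for comparison. Compound 2 `COc1ccc(-c2c(Br)c(=O)c3c(OC)cc(OC)cc3n2S(=O)(=O)c2ccc(OC)cc2)cc1` is likewise recorded as "not determined" (no result reported) and adds no number either. Compound 3 `COC(=O)c1cc(=O)c2c(OC)cc(OC)cc2[nH]1` gives > 34400 nM as a limit of the assay and not as a number. For the measured compounds named here, the series therefore has only the limit of > 34400 nM in this assay, at which 1 of the 3 values shown sits, as its reference point, and no compound yet has a measured half-maximal effective concentration.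

The next compound is compound 4 `COC(=O)c1cc(=O)c2c(OC)cc(OC)cc2n1C` and the change is methyl in place of hydrogen on an aromatic nitrogen with methyl in place of hydrogen on an aromatic nitrogen, ortho to a methoxycarbonyl group. The rest of the structure of compound 3 stays the same.

Going by the values given here, no pair of measured compounds shows what this change does, so the expectation in this assay is for no shift beyond the scatter, with neither direction favoured. This expectation rests on compound 3 with its limit of > 34400 nM as the only anchor. The estimated at least 1.1-fold lower number from compound 3 to compound 4 (0.05 log units; that floor lies within the scatter) is small, and the result may well come back as a limit again. For compound 4 the expected value is 30000 nM with an estimated range of 10000 nM to 80000 nM for now.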

Compound 4, half-maximal effective concentration: 773 nM
For compound 4 the middle estimate is 39-fold (1.59 log units) above the measured one; the whole stated range lies above it.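

In this assay, methyl in place of hydrogen on the aromatic nitrogen, ortho to a methoxycarbonyl group, gives an at least 44-fold lower number from compound 3 to compound 4 (1.64 log units; beyond the scatter), so this nitrogen is a position where a single added carbon moves the read-out well beyond the scatter, and the hydrogen on it is not required for activity in this assay. For the compounds shown here, with this change, compound 4 becomes the first compound with a measured half-maximal effective concentration, 773 nM, and so the first real number against which later changes can be read. The true size of the step stays unknown and only its lower bound is given, since the other end of it is a limit of the assay and not a number: the limit of > 34400 nM in this assay, at which 1 of the 4 values shown sits.

The compounds shown leave open whether the gain belongs to methyl alone or extends to an ethyl group or a longer chain on this nitrogen. They also leave open whether it survives a carboxylic acid or an amide in place of the methoxycarbonyl group, as compound 1 also carries methyl on the nitrogen but offers no number for comparison.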